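Dimethylcarbamoyl for dimethylsulfamoyl in a sulfonamide series

This account rests on a few compounds, and the source may have more. Where it says the series, first, only, none or still open, it means among the compounds named here.

Among the measured compounds shown here, compound 1 `COc1ccc(-c2cc(-c3ccc(S(=O)(=O)N(C)C)cc3)cnc2N)cn1` is the one member of this small set with a definite number: in an in vitro ADME assay on microsomes from liver (Homo sapiens) for metabolic stability (on this read-out higher numbers stand for fast clearance and lower numbers for slow clearance), compound 1 gives 98.8 mL.min-1.g-1. The other two values shown are limits of the assay (the limit of < 7 mL.min-1.g-1 in this assay, at which 2 of the 3 values shown sit). Compound 2 `COc1ccc(-c2cc(-c3ccc(S(N)(=O)=O)cc3)cnc2N)cn1` reaches only the limit < 7 mL.min-1.g-1 in this assay. Compound 3 `COc1ccc(-c2cc(-c3ccc(S(C)(=O)=O)c(F)c3)cnc2N)cn1` likewise gives the limit < 7 mL.min-1.g-1 in this assay. For the measured compounds named here, the only measured step is an at least 14-fold lower number from compound 1 to compound 2 (1.14 log units; beyond the scatter).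

The change now followed is dimethylcarbamoyl in place of dimethylsulfamoyl on an aromatic carbon, giving compound 4 `COc1ccc(-c2cc(-c3ccc(C(=O)N(C)C)cc3)cnc2N)cn1`. The measured step bears on it only in part: that step removed the two methyl groups from the sulfonyl nitrogen and brought a large drop, whereas compound 4 keeps the dimethylamino group and exchanges the sulfonyl for a carbonyl. Going by the values given here, no measured step reports the effect of that exchange. The expectation is therefore a modest fall rather than a repeat of the large drop, with wide uncertainty: compound 4 is estimated at 50 mL.min-1.g-1, between 12 mL.min-1.g-1 and 150 mL.min-1.g-1, that is, an expected 2.0-fold lower number from compound 1 to compound 4 (0.30 log units; within the scatter).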

Compound 4, intrinsic clearance in microsomes: 11.1 mL.min-1.g-1
Estimate against measurement, compound 4: 4.5-fold (0.65 log units) above, and the stated range ends above it.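

At this place, on an aromatic carbon para to a large group, exchanging the dimethylsulfamoyl group for dimethylcarbamoyl changes the number in this assay by itself: the step is an 8.9-fold lower number from compound 1 to compound 4 (0.95 log units; beyond the scatter). Among the compounds shown here, compound 4 keeps the dimethylamino group, so the loss of the two methyl groups seen in compound 2 is not the only single change that takes compound 1 to a much lower number. The comparison with the sulfamoyl group gives only a floor, an at least 1.5-fold higher number from compound 2 to compound 4 (0.20 log units; that floor lies within the scatter), which does not separate the two, and it rests on a limit: the limit of < 7 mL.min-1.g-1 in this assay, at which 2 of the 4 values shown sit.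

The compounds shown leave open how a primary carboxamide or an N-methyl carboxamide would compare with compound 4 at this place. They also leave open whether a nitrile or a carboxylic acid there would follow the dimethylcarbamoyl group.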